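The compounds below may be only part of what the source reports. "The series", "measured", "known", "first", "only" and "open" are said of these compounds alone.

In a physicochemical assay for solubility, at pH 7.4 (a lower number here means a less soluble compound, a higher number a more soluble compound), compound 1 (`NS(=O)(=O)c1ccc(S(=O)(=O)CCCO)c(F)c1`) gives 6600 ug/mL and compound 2 (`COC(=O)c1cc(S(N)(=O)=O)ccc1S(=O)(=O)CCCO`) gives 14000 ug/mL as its reading. Compound 3 (`Nc1cc(S(N)(=O)=O)ccc1S(=O)(=O)CCO`) gives 13200 ug/mL as its reading, within the scatter of both compound 1 and compound 2. Compound 4 (`Nc1cc(S(N)(=O)=O)ccc1S(=O)(=O)CCCO`) differs from compound 3 by hydroxymethyl in place of hydroxy on a saturated chain carbon, two bonds along the chain from a sulfonyl sulfur on the chain: hydroxymethyl in place of hydroxy on a saturated chain carbon, two bonds along the chain from a sulfonyl sulfur, which also reads 2-hydroxyethyl to 3-hydroxypropyl. Among the measured compounds shown here, no measured step covers this change. For the measured compounds named here, the only measured step (a 2.1-fold higher number from compound 1 to compound 2 (0.33 log units; beyond the scatter)) is modest and falls on an aromatic carbon, so it serves only as a gauge of how far numbers move. Compound 1 and compound 2 already carry the 3-hydroxypropyl chain, and neither value falls outside the scatter of compound 3. No step beyond the scatter is therefore expected in this assay from the chain change, with a slight lean to a lower number. The estimated change is small (a 1.2-fold lower number from compound 3 to compound 4 (0.08 log units; within the scatter)). For compound 4 the expected value is 11000 ug/mL (estimated range 5500 ug/mL to 20000 ug/mL).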

Compound 4, solubility: 8400 ug/mL
Compound 4: middle estimate off by 1.3-fold (0.12 log units), on the high side; the measured number falls inside the stated range.
By their numbers in this assay, from the lowest: compounds 1, 4, 3 and 2 (each within the scatter of the next, the first and the last beyond it).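

In this assay the chain change now has a measured step of its own (a 1.6-fold lower number from compound 3 to compound 4 (0.20 log units; within the scatter)), so 2-hydroxyethyl to 3-hydroxypropyl on a saturated chain carbon, two bonds along the chain from a sulfonyl sulfur, stays within the scatter. Compound 4 also gives an amino member of the 3-hydroxypropyl set, and both aromatic changes to amino stay within the scatter (a 1.7-fold lower number from compound 2 to compound 4 (0.22 log units; within the scatter); a 1.3-fold higher number from compound 1 to compound 4 (0.10 log units; within the scatter)), while only the fluoro to methoxycarbonyl step (a 2.1-fold higher number from compound 1 to compound 2 (0.33 log units; beyond the scatter)) lies beyond it. No evidence bears on what lies behind any of these steps.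

Among the compounds shown here, the chain step rests on the single amino pair, so its size with fluoro or methoxycarbonyl on the aromatic carbon stays open. Also open, going by these compounds, is whether a longer chain, or a chain ending in a carboxylic acid or an amine, would stay within the same scatter.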